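Chloro in place of hydrogen next to the ring nitrogen

The source may hold more compounds than are shown below. What is called first, only, known or untested is meant among the compounds shown, and "the series" means these compounds.

Compound 1 `c1ccc(-c2cc3n(n2)CCCC3)nc1` gives 1290 nM in a functional assay on HEK293 cells for negative allosteric modulation of metabotropic glutamate receptor 5 (Rattus norvegicus), read by FLIPR and calcium flux, with a stated time of 170 s (on this read-out lower numbers stand for stronger inhibition and higher numbers for weaker inhibition), the only plain number shown in the series. Compound 2 `N#Cc1ccc(-c2cc3n(n2)CCCC3)nc1` reaches only the assay limit of > 10000 nM in this assay. The step of an at least 7.7-fold higher number from compound 1 to compound 2 (0.88 log units; beyond the scatter) is therefore a lower bound, set by the limit of > 10000 nM in this assay, at which 1 of the 2 values shown sits. Compound 3 `Clc1cccc(-c2cc3n(n2)CCCC3)n1` differs from compound 1 by chloro in place of hydrogen on an aromatic carbon, a different group from the cyano of compound 2 and at its own position, so that measured step bears only loosely on it. For compound 3 a modest weakening is expected, a 1.9-fold higher number from compound 1 to compound 3 (0.29 log units; within the scatter). Compound 3 is estimated at 2500 nM, range 700 nM to 9000 nM, in this assay.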

Compound 3, half-maximal inhibitory concentration: 1520 nM
Estimate against measurement, compound 3: 1.6-fold (0.22 log units) above; the measured number falls inside the stated range.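

In this assay, a 1.2-fold higher number from compound 1 to compound 3 (0.07 log units; within the scatter), so chloro on the aromatic carbon next to the ring nitrogen leaves the inhibition of compound 1 unchanged within the scatter. This gives the series its first substituent with a plain number, showing that this position accepts one chlorine atom without a measurable loss. Nothing shown gives a reason for this result.

As far as these compounds go, whether an amine, a methoxy group or a longer chain on this same carbon would also be accepted remains open. The effect of a nitrile at this position is also unknown, as is that of chloro at the position of the nitrile in compound 2.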